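Moving the chloro on the benzoyl ring of a urotensin-2 ligand

A few compounds are considered here, and "the series" means these few. Any claim that something is new, unique, unknown or untested is made for them only; others in the source may bear on it.

Compound 1 `COc1cccc(C(=O)NC(CCN(C)C)c2ccc(Cl)cc2)c1C` and compound 2 `Cc1c(Cl)cccc1C(=O)NC(CCN(C)C)c1ccc(Cl)cc1` share a core that carries a dimethylaminoethyl chain and a 4-chlorophenyl group, and differ only on the benzoyl ring. In an assay on NIH3T3 cells with Urotensin-2 receptor (Homo sapiens) as the target (a lower number here means that less compound is needed, a higher number that more compound is needed for the effect), compound 1 gives 4270 nM, while compound 2 gives 1740 nM. Within the data shown here, the single step between them, a 2.5-fold lower number from compound 1 to compound 2 (0.39 log units; beyond the scatter), is chloro in place of methoxy on an aromatic carbon. Among the measured compounds shown here, compound 2 thus stands at the lower of the two numbers measured so far, with compound 1 above it.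

Compound 3 `Cc1cccc(Cl)c1C(=O)NC(CCN(C)C)c1ccc(Cl)cc1` keeps every atom of compound 2 but joins them differently: 2-chloro-6-methylphenyl in place of 3-chloro-2-methylphenyl on a carbonyl carbon. For the measured compounds named here, no measured step concerns a rearrangement of substituents around the benzoyl ring; the only step available, a 2.5-fold lower number from compound 1 to compound 2 (0.39 log units; beyond the scatter), concerns the identity of a substituent, not its placement, so it bears on the change only loosely. The expected step of a 1.4-fold higher number from compound 2 to compound 3 (0.16 log units; within the scatter) is therefore estimated to be small, with no direction favoured beyond the scatter. For compound 3 in this assay the estimate is 2500 nM, expected to fall between 800 nM and 8000 nM.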

Compound 3, half-maximal effective concentration: 5130 nM
The estimate for compound 3 lay 2.1-fold (0.31 log units) below the measured number; the measured number falls inside the stated range.
By their numbers in this assay, from the lowest: compound 2; then compounds 1 and 3 (each within the scatter of the next).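

Placement on the benzoyl ring matters as well as the identity of the substituent: with the same atoms in this assay, 2-chloro-6-methylphenyl in place of 3-chloro-2-methylphenyl on a carbonyl carbon gives a 2.9-fold higher number from compound 2 to compound 3 (0.47 log units; beyond the scatter). The earlier step showed only that exchanging methoxy for chloro could shift the number, whereas this one shows that a shift beyond the scatter can occur with no change in atoms, heavy-atom count or counted hydrogen-bond donors and acceptors in the group. Nothing available accounts for the shift, so the result stands as an observation without an explanation.

The compounds shown cover only two arrangements of chloro and methyl on this ring, so they leave open how other arrangements of the same pair would compare, and whether the effect of rearrangement would carry over to a ring bearing methoxy. They also leave open how a fluoro, a nitrile, an amine or a carboxylic acid would behave on this ring, and whether a longer chain in place of the dimethylaminoethyl chain would change the effect of placement.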